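The compounds below may be only part of what the source reports. "The series", "measured", "known", "first", "only" and "open" are said of these compounds alone.

In a functional assay on LNCaP cells (Homo sapiens) for antiproliferative activity, read by luminescence, with a stated time of 96 h (on this read-out lower numbers stand for stronger inhibition and higher numbers for weaker inhibition), compound 1 `CC1(C)Oc2cc(NS(=O)(=O)c3ccccc3)ccc2NC1=O` gives 7520 nM and compound 2 `COc1cc2c(cc1NS(=O)(=O)c1cc(Br)ccc1OC)OC(C)(C)C(=O)N2` gives 4410 nM. For the measured compounds named here, these are the only two measured compounds so far, and their values lie within the scatter of each other, so compound 2 cannot be placed ahead of compound 1 on these numbers.

Compound 3 `COc1ccc(Br)cc1S(=O)(=O)Nc1ccc2c(c1)OC(C)(C)C(=O)N2` comes from compound 2 by a single change, hydrogen in place of methoxy on an aromatic carbon. The carbon concerned is ortho to a large group.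

Going by the values given here, no step between measured compounds bears on this change, so the data give no direct size for it. Among the compounds with values here, the only anchor is compound 2 at 4410 nM. In this assay the expectation is therefore a step no larger than the scatter, with no firm direction, and the range has to stay wide. The estimated step is a 1.3-fold lower number from compound 2 to compound 3 (0.10 log units; within the scatter). For compound 3 the expected value is 3500 nM, with an estimated range of 1200 nM to 10000 nM.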

Compound 3, half-maximal inhibitory concentration: 6280 nM
For compound 3 the middle estimate is 1.8-fold (0.25 log units) below the measured one; the measured number falls inside the stated range.
By their numbers in this assay, from the lowest: compounds 2, 3 and 1 (each within the scatter of the next).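

In this assay, hydrogen in place of methoxy on this aromatic carbon, ortho to a large group and para to a fused ring, gives a 1.4-fold higher number from compound 2 to compound 3 (0.15 log units; within the scatter), the first single-place step measured in the series. Compounds 2 and 3 therefore cannot be told apart on this read-out, and the methoxy at this position is not shown to be needed for the activity seen here, even though the change takes away 2 heavy atoms and 1 hydrogen-bond acceptor. No measurement is available that would account for the size of this step.

As far as these compounds go, whether another group on this carbon, such as an amine, a fluorine atom or a longer alkoxy chain, would give a step beyond the scatter remains open, as only hydrogen and methoxy are compared here. Compound 1 differs from compound 3 in more than one place, so the separate contributions of the bromo and methoxy groups on the sulfonyl side also remain unresolved.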